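Swapping One Thiophene for Another on the Shared Core

A few compounds are considered here, and "the series" means these few. Any claim that something is new, unique, unknown or untested is made for them only; others in the source may bear on it.

compound 1 `Cc1ccsc1-c1cc(-c2ccc(Cl)o2)cc(-c2cccc(Cl)c2)n1` — 5.9%
compound 2 `Cc1ccsc1-c1cc(-c2ccc(Cl)o2)cc(-c2cccnc2)n1` — 21.4%

In an assay on isolated protein for inhibition of DNA topoisomerase 1 (Homo sapiens), with a stated time of 30 min, tested at 100 uM (on this read-out higher numbers stand for more inhibition at the one concentration tested (going by the name of the read-out) and lower numbers for less inhibition), compound 1 gives 5.9%, the lowest of the two numbers seen. For the measured compounds named here, the only measured step is a number 15.5 percentage points higher from compound 1 to compound 2 (beyond the scatter), which alters a different ring. Compound 3 `Clc1cccc(-c2cc(-c3ccc(Cl)o3)cc(-c3ccc(Cl)s3)n2)c1` differs from compound 1 by 5-chlorothiophen-2-yl in place of 3-methylthiophen-2-yl on an aromatic carbon. Going by the values given here, no measured step replaces one thiophene substituent with another, so that step offers no direct guide here. A step of no more than the scatter is therefore expected, a number 2.1 percentage points higher from compound 1 to compound 3 (within the scatter). Compound 3 is estimated at 8%, within 0% to 22%.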

Compound 3, a percentage reported as inhibition, at one concentration (the size of the read-out at that concentration, not a potency): 13.3%
Estimate against measurement, compound 3: 5.3 percentage points below; low and high end bracket the measured number.
By their numbers in this assay, from the lowest: compounds 1, 3 and 2 (each within the scatter of the next, the first and the last beyond it).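

At the carbon next to the ring nitrogen, 5-chlorothiophen-2-yl in place of 3-methylthiophen-2-yl in this assay gives a number 7.4 percentage points higher from compound 1 to compound 3 (within the scatter) and so does not separate the two substituted thiophenes. For the compounds shown here, this is the first reading at this position, and unlike the pyridin-3-yl change on the other ring, this exchange stays within the scatter. Nothing available explains this result. From the compounds shown here alone, whether an amine or a carboxylic acid at this position would read differently stays open, as does whether the pyridin-3-yl step carries over to the core bearing 5-chlorothiophen-2-yl.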